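The compounds below may be only part of what the source reports. "The series", "measured", "known", "first", "only" and "open" are said of these compounds alone.

Compound 1 `O=C(O)c1ccc2noc(-c3ccc(Oc4ccccc4)cc3)c2c1` and compound 2 `O=C(O)c1ccc2noc(-c3ccc(Oc4ccccn4)cc3)c2c1` share one core and differ only by pyridin-2-yl in place of phenyl on an oxygen on an aromatic ring. In an assay for inhibition of inositol hexakisphosphate kinase 3 (Homo sapiens), read by colorimetric assay, coupled enzyme assay and malachite green, with a stated time of 120 min, in the presence of a further agent that is not named here (on this read-out higher numbers stand for weaker inhibition and lower numbers for stronger inhibition), compound 1 gives 550 nM, and compound 2 gives 2060 nM; that change made a 3.7-fold higher number from compound 1 to compound 2 (0.57 log units; beyond the scatter). Compound 3 `O=C(O)c1ccc2noc(-c3cccc(Oc4ccccc4)c3)c2c1` has the same atoms as compound 1 joined differently, and the difference between the two cores is not broken down here. In this assay compound 3 gives 850 nM, a number within the usual scatter of compound 1. Compound 4 `O=C(O)c1ccc2noc(-c3cccc(Oc4ccccn4)c3)c2c1` has not yet been measured; it differs from compound 3 by pyridin-2-yl in place of phenyl on an oxygen on an aromatic ring, the same change as from compound 1 to compound 2. A step of similar size is expected for compound 4, a 3.5-fold higher number from compound 3 to compound 4 (0.55 log units; beyond the scatter), because the same change earlier gave a 3.7-fold higher number from compound 1 to compound 2 (0.57 log units; beyond the scatter). Compound 4 is therefore estimated at 3000 nM, most likely between 1500 nM and 6500 nM.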

Compound 4, half-maximal inhibitory concentration: 10900 nM
Estimate against measurement, compound 4: 3.6-fold (0.56 log units) below, and the stated range ends below it.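

On the core of compound 3, putting pyridin-2-yl in place of phenyl on the oxygen gave a 13-fold higher number from compound 3 to compound 4 (1.11 log units; beyond the scatter) in this assay, so the direction seen on the core of compound 1 carried over. The size did not carry over, and the two steps differ: the same change on two cores in this assay, a 3.7-fold higher number (0.57 log units; beyond the scatter) from compound 1 to compound 2 and a 13-fold higher number (1.11 log units; beyond the scatter) from compound 3 to compound 4, 3.4-fold (0.53 log units) apart, beyond the scatter of two such steps Across these two pairs, the change therefore weakens inhibition both times, but the step on one core did not give its size on the other, and these numbers do not show why the cores differ.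

Going by these compounds, it remains open whether another group on the oxygen, such as cyclohexyl, would also give steps that differ between the two cores. On these data alone, the effect of an amide in place of the carboxylic acid also remains open.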